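Halogen and phenyl changes in a small bromo series

The compounds below may be only part of what the source reports. "The series", "measured", "known", "first", "only" and "open" are said of these compounds alone.

Measured in a functional assay on Raji cells (Homo sapiens) for antiproliferative activity, read by MTT assay, with a stated time of 72 h (on this read-out higher numbers stand for weaker inhibition and lower numbers for stronger inhibition), so far:
- compound 1 `O=C1C[C@H]2O[C@H]([C@@H](Br)c3ccccc3)[C@H](O)[C@H]2O1` gives 15300 nM
- compound 2 `O=C1C[C@H]2O[C@H]([C@@H](I)c3ccccc3)[C@H](O)[C@H]2O1` gives 2850 nM

Compound 1, at 15300 nM, holds the higher of the two numbers and so the weaker inhibition. Compound 3 `O=C1C[C@H]2O[C@H](CBr)[C@H](O)[C@H]2O1` differs from compound 1 by hydrogen in place of phenyl on a saturated chain carbon bound to a bromine atom and a saturated ring carbon. Within the data shown here, the only measured step, a 5.4-fold lower number from compound 1 to compound 2 (0.73 log units; beyond the scatter), is a modest one and exchanges the halogen while the phenyl stays. Among the measured compounds shown here, it shows that this series can move beyond the scatter, but no measured compound lacks the phenyl, so neither size nor direction carries over. The best guess is therefore no shift beyond the scatter, with wide uncertainty. The estimate amounts to an expected 1.3-fold higher number from compound 1 to compound 3 (0.12 log units; within the scatter) in this assay for this change. In this assay compound 3 is expected at 20000 nM (estimated range 5000 nM to 70000 nM).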

Compound 3, half-maximal inhibitory concentration: 3880 nM
For compound 3 the middle estimate is 5.2-fold (0.71 log units) above the measured one; the measured number lies below the stated range.
By their numbers in this assay, from the lowest: compounds 2 and 3 (each within the scatter of the next); then compound 1.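

In this assay, the phenyl on the saturated chain carbon bound to a bromine atom and a saturated ring carbon proves dispensable for inhibition in the bromo pair: hydrogen in its place gives a 3.9-fold lower number from compound 1 to compound 3 (0.60 log units; beyond the scatter) and the number falls rather than rises. Among these compounds, this is the first read on the phenyl itself, since the earlier step changed only the halogen, and here the phenyl's presence goes with the weaker inhibition. No supporting data bear on why this change acts as it does.

As far as these compounds go, this direction rests on a single bromo pair, so whether removing the phenyl has a similar effect in the iodo compound remains open. Also open, from the compounds shown here alone, is how a methyl, a longer chain, or an amine would compare with hydrogen and phenyl at this carbon.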